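Compound 4: a hydroxy variant of compound 3

This account rests on a few compounds, and the source may have more. Where it says the series, first, only, none or still open, it means among the compounds named here.

Measured so far in a functional assay on HEK293 cells for agonist activity at D(4) dopamine receptor (Homo sapiens), read by FLIPR; a lower number here means that less compound is needed, a higher number that more compound is needed for the effect:
compound 1 `Cc1cccc(NC(=O)CN2CCC(c3nccs3)CC2)c1`: 1 nM
compound 2 `Cc1cccc(NC(=O)CN2CCC(c3ccc(O)cc3)CC2)c1`: 70 nM
compound 3 `Cc1cccc(NC(=O)CN2CCC(c3ccccc3)CC2)c1`: 170 nM

Compound 3 carries the highest of the three numbers. Its nearest neighbour is compound 2, with a modest step of a 2.4-fold higher number from compound 2 to compound 3 (0.39 log units; beyond the scatter); the furthest is compound 1, with a large step of a 170-fold higher number from compound 1 to compound 3 (2.23 log units; beyond the scatter), and the same kind of large gap is seen in a 70-fold higher number from compound 1 to compound 2 (1.85 log units; beyond the scatter).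

Compound 4 `Cc1cccc(NC(=O)CN2CCC(c3cccc(O)c3)CC2)c1` differs from compound 3 in one place: hydroxy in place of hydrogen on an aromatic carbon. Within the data shown here, only the step between compound 2 and compound 3 bears on this, since it also concerns a hydroxy on the six-membered carbon ring, though there the group sat in a different position. That step was modest, so a modest lowering of the number, or no step beyond the scatter, is what is expected on going to compound 4; the expected step is a 1.7-fold lower number from compound 3 to compound 4 (0.23 log units; within the scatter). For compound 4 in this assay the estimate is 100 nM, with a range from 40 nM to 300 nM.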

Compound 4, half-maximal effective concentration: 8 nM
For compound 4 the middle estimate is 13-fold (1.10 log units) above the measured one; measured number below the stated range.
By their numbers in this assay, from the lowest: compound 1; then compound 4; then compound 2; then compound 3.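

In this assay, a hydroxy group on the phenyl ring can matter far more than compound 2 suggested: as 3-hydroxyphenyl it gives a 21-fold lower number from compound 3 to compound 4 (1.33 log units; beyond the scatter) and so a large step, where the 4-hydroxyphenyl group gave only a modest one. The place of the hydroxy therefore counts in its own right, with an 8.8-fold lower number from compound 2 to compound 4 (0.94 log units; beyond the scatter) between the two hydroxyphenyl compounds. The 3-hydroxyphenyl group still falls short of the 1,3-thiazol-2-yl group, with an 8.0-fold higher number from compound 1 to compound 4 (0.90 log units; beyond the scatter) remaining, and no measurement at hand explains either the gain or the dependence on place.

From the compounds shown here alone, whether a methoxy group, an amine or a carboxylic acid at the same place would keep the number near that of compound 4 stays open. Also open, going by these compounds, is how an added hydroxy or amine would act on the 1,3-thiazol-2-yl group of compound 1.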